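A few compounds are considered here, and "the series" means these few. Any claim that something is new, unique, unknown or untested is made for them only; others in the source may bear on it.

Measured in a functional assay on NCI-H1650 cells (Homo sapiens) for inhibition, read by sulforhodamine B assay, with a stated time of 3 days; a lower number here means a stronger inhibitor, a higher number a weaker inhibitor:
- compound 1 `O=C1Nc2ccccc2/C1=C\C(=O)c1c[nH]c2ccccc12`: 1270 nM
- compound 2 `O=C1Nc2ccc(F)cc2/C1=C\C(=O)c1cnc2ccc(Cl)nn12`: 2730 nM
- compound 3 `CN1CCN(c2cccc(N/C=C3\C(=O)Nc4ccc(NC(=O)c5cccc(F)c5)cc43)c2)CC1`: 4280 nM

Compound 3 at 4280 nM cannot be told apart from compound 2 at 2730 nM. It is a weaker inhibitor, beyond the scatter, than compound 1 at 1270 nM.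

Compound 4 `CC(C)CC(=O)Nc1ccc2c(c1)/C(=C/Nc1cccc(N3CCN(C)CC3)c1)C(=O)N2` has isobutyl in place of 3-fluorophenyl on a carbonyl carbon. Among the compounds with values here, no measured pair shows this change, so the only anchor is compound 3 at 4280 nM. In this assay the expected step of a 1.1-fold lower number from compound 3 to compound 4 (0.03 log units; within the scatter) is none beyond the scatter, in either direction. For compound 4 the estimated value is 4000 nM, with an expected range of 1500 nM to 11000 nM.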

Compound 4, half-maximal inhibitory concentration: 5870 nM
Estimate against measurement, compound 4: 1.5-fold (0.17 log units) below; the measured number falls inside the stated range.
By their numbers in this assay, from the lowest: compound 1; then compounds 2, 3 and 4 (each within the scatter of the next, the first and the last beyond it).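

In this assay, isobutyl in place of 3-fluorophenyl on a carbonyl carbon gives a 1.4-fold higher number from compound 3 to compound 4 (0.14 log units; within the scatter). In this one pair, the aromatic ring and its fluorine can therefore be exchanged for a smaller open chain with no difference that stands clear of the scatter. No measured evidence explains this result.

The compounds shown leave open whether a longer chain, an amine or a carboxylic acid at this place would separate from compound 3 and compound 4. Plain phenyl would show whether the fluorine matters on its own.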